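The source may hold more compounds than are shown below. What is called first, only, known or untested is meant among the compounds shown, and "the series" means these compounds.

Measured so far:
- compound 1, `CC(=O)N1N=C(c2ccc(F)cc2)CC1c1cn(-c2ccccc2)nc1-c1ccc(Br)cc1`: 71%
- compound 2, `CC(=O)N1N=C(c2ccc(F)cc2)CC1c1cn(-c2ccccc2)nc1-c1cccc([N+](=O)[O-])c1`: 109%
- compound 3, `Fc1ccc(C2=NN(c3ccccc3)C(c3cn(-c4ccccc4)nc3-c3ccc(Br)cc3)C2)cc1`: 71%

In a functional assay on the whole organism (Tail) with Rattus norvegicus as the target, in the tail flick test, with a stated time of 60 min, at a dose of 25 mg/kg by the oral route (on this read-out higher numbers stand for more inhibition at the one dose given (going by the name of the read-out) and lower numbers for less inhibition), compound 3 stands level with compound 1 at the digits given, the two together the lowest of the three numbers; the step of no change at the digits printed from compound 1 to compound 3 (within the scatter) lies within the scatter, so the change of phenyl for acetyl on the ring amine nitrogen made no resolved difference. Among the measured compounds shown here, the one resolved step in the set is a number 38 percentage points higher from compound 1 to compound 2 (beyond the scatter), which is large and beyond the scatter.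

Compound 4, `O=[N+]([O-])c1cccc(-c2nn(-c3ccccc3)cc2C2CC(c3ccc(F)cc3)=NN2c2ccccc2)c1`, is still to be measured in this assay. Its difference from compound 3 is 3-nitrophenyl in place of 4-bromophenyl on an aromatic carbon. This is the same exchange that was made between compound 1 and compound 2, there on the acetyl-bearing core, here on the phenyl-bearing core. That step was large and upward, and the core exchange itself showed no effect, so a step of similar size and direction is expected here, a number 31 percentage points higher from compound 3 to compound 4 (beyond the scatter). Compound 4 is therefore estimated at 102%, with a range from 82% to 118%.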

Compound 4, a percentage reported as inhibition, in the whole organism at one dose (the size of the read-out at that dose, not a potency): 108%
Beside the measured number, compound 4's estimate is 6 percentage points below it; the measured number falls inside the stated range.
By their numbers in this assay, from the lowest: compounds 1 and 3 (each within the scatter of the next); then compounds 4 and 2 (each within the scatter of the next).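

In this assay, 3-nitrophenyl in place of 4-bromophenyl on the aromatic carbon of the five-membered ring gives a number 37 percentage points higher from compound 3 to compound 4 (beyond the scatter), so the change at this position also holds on the phenyl-bearing core and is not confined to the acetyl-bearing one, with a step of matching size: the same change on two cores in this assay, a number 38 percentage points higher (beyond the scatter) from compound 1 to compound 2 and a number 37 percentage points higher (beyond the scatter) from compound 3 to compound 4, 1 percentage points apart, within the scatter of two such steps. Phenyl in place of acetyl on the ring amine nitrogen now gives a number 1 percentage points lower from compound 2 to compound 4 (within the scatter), so that exchange leaves no resolved difference with either of the two aryl groups: the same change on two cores in this assay, no change at the digits printed (within the scatter) from compound 1 to compound 3 and a number 1 percentage points lower (within the scatter) from compound 2 to compound 4, 1 percentage points apart, within the scatter of two such steps. Across these four compounds, the two changes therefore behave as independent of each other in this assay.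

The compounds shown do not separate the effect of the nitro group from that of its place on the phenyl ring. Also open, going by these compounds, is what a phenyl ring carrying an amine or a carboxylic acid would give at this carbon.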